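Chlorobenzyl for phenylpropyl on the piperidine nitrogen

A few compounds are considered here, and "the series" means these few. Any claim that something is new, unique, unknown or untested is made for them only; others in the source may bear on it.

Measured compounds:
Compound 1, `COc1ccc2nccc(C3CN(C4CCN(Cc5cc6ccccc6s5)CC4)C(=O)O3)c2c1`: 794 nM
Compound 2, `COc1ccc2nccc(C3CN(C4CCN(CCCc5ccccc5)CC4)C(=O)O3)c2c1`: 251 nM

Among the compounds with values here, in an in vitro functional assay on RBL cells for antagonist activity at C-C chemokine receptor type 8 (Homo sapiens), read by FLIPR and calcium flux (a lower number here means a stronger inhibitor, a higher number a weaker inhibitor), compound 2 gives the lower of the two numbers measured so far, and its nearest neighbour is compound 1. Within the data shown here, the one measured step, a 3.2-fold lower number from compound 1 to compound 2 (0.50 log units; beyond the scatter), shows what replacing an aromatic group bound directly to the chain carbon by a longer chain did. Compound 3, `COc1ccc2nccc(C3CN(C4CCN(Cc5ccccc5Cl)CC4)C(=O)O3)c2c1`, reverses part of that move: 2-chlorophenyl in place of phenethyl on a saturated chain carbon bound to an amine nitrogen in a ring. Among the measured compounds shown here, the aryl group again sits on the carbon bound to the ring amine, as in compound 1, though the aryl group itself differs from the one in compound 1, so the step from compound 1 to compound 2 bears on it only partly. Compound 3 is therefore expected to give a modestly higher number, a 2.0-fold higher number from compound 2 to compound 3 (0.30 log units; within the scatter), landing between the two measured values. The estimate for compound 3 is 500 nM, with a range from 160 nM to 1600 nM.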

Compound 3, half-maximal inhibitory concentration: < 50200 nM
Compound 3: only a limit was reported (the forecaster's own chance of this, stated with the estimate: 3%); the middle value does not contradict the limit.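

Within the data shown here, compound 3 is reported only as a limit, < 50200 nM, so no step from compound 1 or compound 2 to compound 3 can be read. The compounds shown leave open how 2-chlorophenyl in place of phenethyl changes the number, and in which direction.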